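The compounds below may be only part of what the source reports. "The series", "measured", "known", "first", "only" and "open" are said of these compounds alone.

Compound 1 `c1ccc(-c2cnoc2)c(NCC2=NCCN2)c1` in a functional assay for activation of Alpha-1B adrenergic receptor (Homo sapiens), read by calcium flux (on this read-out higher numbers stand for an effect only at larger amounts of compound and lower numbers for an effect already at smaller amounts), gives only a limit, < 100000 nM. Compound 2 `Cc1ccc(-c2ccccc2NCC2=NCCN2)o1` in this assay gives 46.8 nM. Compound 3 `c1cnc(-c2ccccc2NCC2=NCCN2)nc1` in this assay gives 77.6 nM.

Compound 3 stands highest of the two numbers shown; the nearest is the step of a 1.7-fold higher number from compound 2 to compound 3 (0.22 log units; within the scatter), which lies within the scatter. The remaining value is a limit (the limit of < 100000 nM in this assay, at which 1 of the 3 values shown sits). Compound 4 `CO/N=C(\C)c1ccccc1NCC1=NCCN1` differs from compound 3 by a group of 5 heavy atoms (3 carbon, 1 nitrogen, 1 oxygen; no ring) in place of a group of 6 heavy atoms (4 carbon, 2 nitrogen; one six-membered aromatic ring with 2 hetero atoms), on an aromatic carbon. Going by the values given here, the steps a step that the limit leaves unreadable from compound 1 to compound 2 and a step that the limit leaves unreadable from compound 1 to compound 3 cannot be sized, and a 1.7-fold higher number from compound 2 to compound 3 (0.22 log units; within the scatter) stays within the scatter; no measured step replaces a ring with a chain. In this assay no step beyond the scatter is therefore expected, though with wide uncertainty. Compound 4 is estimated at 100 nM, between 25 nM and 400 nM. That estimate means a 1.3-fold higher number from compound 3 to compound 4 (0.11 log units; within the scatter).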

Compound 4, half-maximal effective concentration: < 5020 nM
Compound 4: only a limit was reported; the forecaster's own chance of this, stated with the estimate: 10%; the middle value does not contradict the limit.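

Compound 4 gives only a limit in this assay, so its steps from compound 1, compound 2 and compound 3 cannot be read: the limit of < 5020 nM in this assay, at which 1 of the 4 values shown sits.

The compounds shown leave open how the ringless group of compound 4 compares with the pyrimidin-2-yl of compound 3.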